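The source may hold more compounds than are shown below. What is called first, only, known or untested is meant among the compounds shown, and "the series" means these compounds.

Measured so far in a functional assay on A549 cells (Homo sapiens) for inhibition, read by MTT assay, with a stated time of 72 h; on this read-out lower numbers stand for stronger inhibition and higher numbers for weaker inhibition:
compound 1, `CC(O)c1cn(Cc2cc(=O)oc3cc(O)ccc23)nn1`: compound 1 gives > 100000 nM, a limit of the assay
compound 2, `CC(C)(C)c1cn(Cc2cc(=O)oc3cc(O)ccc23)nn1`: compound 2 gives 67600 nM

Compound 2 holds the only number shown in this assay. For compound 1 only the limit of > 100000 nM in this assay, at which 1 of the 2 values shown sits, is known. Compound 3, `CCCCCCc1cn(Cc2cc(=O)oc3cc(O)ccc23)nn1`, differs from compound 2 by hexyl in place of tert-butyl on an aromatic carbon. Among the measured compounds shown here, the one measured step at this carbon is an at least 1.4-fold lower number from compound 1 to compound 2 (0.17 log units; that floor lies within the scatter), which stays within the scatter and starts from a limit, and no step compares two alkyl groups. For compound 3 no step beyond the scatter is therefore expected, a 1.2-fold lower number from compound 2 to compound 3 (0.09 log units; within the scatter). Compound 3 is estimated at 55000 nM, between 15000 nM and 150000 nM.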

Compound 3, half-maximal inhibitory concentration: 66200 nM
Estimate against measurement, compound 3: 1.2-fold (0.08 log units) below, and the stated range covers the measured number.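

In this assay, among the compounds shown here, the first comparison of two alkyl groups at this aromatic carbon gives a 1.0-fold lower number from compound 2 to compound 3 (0.01 log units; within the scatter), so hexyl and tert-butyl are not told apart here. Hexyl in place of 1-hydroxyethyl gives an at least 1.5-fold lower number from compound 1 to compound 3 (0.17 log units; that floor lies within the scatter), which again leaves the alkyl groups and the hydroxylated group unseparated. Compound 1 stands at a limit, not a number: the limit of > 100000 nM in this assay, at which 1 of the 3 values shown sits.

From the compounds shown here alone, whether an amine, a carboxylic acid or a chain longer than hexyl at this carbon would give a step beyond the scatter stays open. So does the effect of any change on the shared core.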